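Aryl Swap on the Ring Nitrogen of the Shared Core

This account rests on a few compounds, and the source may have more. Where it says the series, first, only, none or still open, it means among the compounds named here.

Measured so far in a functional assay on A549 cells (Homo sapiens) for inhibition, read by MTT assay, with a stated time of 72 h; on this read-out higher numbers stand for weaker inhibition and lower numbers for stronger inhibition:
- compound 1 `Cc1ccc(-n2c(-c3coc4cc(C)c(Cl)cc4c3=O)nc(-c3ccccc3)c2-c2ccccc2)c(C)c1`: 6250 nM
- compound 2 `Cc1ccc(-n2c(-c3coc4cc(C)c(Cl)cc4c3=O)nc(-c3ccccc3)c2-c2ccccc2)cc1`: 12500 nM
- compound 3 `Cc1cc2occ(-c3nc(-c4ccccc4)c(-c4ccccc4)n3-c3cccc([N+](=O)[O-])c3)c(=O)c2cc1Cl`: 6250 nM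

Compound 1 stands level with compound 3 at the digits shown, the two lowest numbers of the three; compound 2 sits furthest from it, a 2.0-fold higher number from compound 1 to compound 2 (0.30 log units; within the scatter).

Compound 4 `Cc1cc2occ(-c3nc(-c4ccccc4)c(-c4ccccc4)n3-c3ccc(Br)cc3)c(=O)c2cc1Cl` differs from compound 1 in one place: 4-bromophenyl in place of 2,4-dimethylphenyl on an aromatic nitrogen.

Going by the values given here, two measured steps bear on this change, both swaps of the aryl group on the same aromatic nitrogen. From compound 1 to compound 3 the number did not move at the digits shown, no change at the digits printed from compound 1 to compound 3 (within the scatter). From compound 2 to compound 3 it moved only a little, a 2.0-fold lower number from compound 2 to compound 3 (0.30 log units; within the scatter). Each of these stayed within the scatter, so a 4-bromophenyl entering in place of the 2,4-dimethylphenyl is expected to give a step of a 1.3-fold higher number from compound 1 to compound 4 (0.11 log units; within the scatter), no clear shift in this assay.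

Compound 4 is therefore estimated at 8000 nM, with a range from 3000 nM to 25000 nM.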

Compound 4, half-maximal inhibitory concentration: 25000 nM
Compound 4: middle estimate off by 3.1-fold (0.49 log units), on the low side, and the stated range covers the measured number.
By their numbers in this assay, from the lowest: compounds 1, 3, 2 and 4 (each within the scatter of the next, the first and the last beyond it).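

The earlier aryl swaps on this aromatic nitrogen all stayed within the scatter, but 4-bromophenyl shows that a change here can move the number beyond it in this assay, giving a 4.0-fold higher number from compound 1 to compound 4 (0.60 log units; beyond the scatter) and a 4.0-fold higher number from compound 3 to compound 4 (0.60 log units; beyond the scatter). The comparison with the closest neighbour is milder, since bromo in place of methyl on the aromatic carbon gives a 2.0-fold higher number from compound 2 to compound 4 (0.30 log units; within the scatter), so 4-methylphenyl and 4-bromophenyl cannot be told apart in this assay. No measurement shown here gives a cause for these steps.

From the compounds shown here alone, it remains open whether 4-chlorophenyl or 4-methoxyphenyl on this nitrogen would give a number closer to that of compound 4 or to that of compound 1. An amine or a carboxylic acid on this phenyl ring is also untested among the compounds shown, so its effect remains unknown.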